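Exchanging the Group on the Carbonyl of Compound 3

The source may report more compounds than this note shows. Statements on the series, on what has been measured and on what is new or still open speak of the compounds shown alone.

In a physicochemical assay for lipophilicity, read by HPLC, in phosphate buffer, measured as octanol-water partition, with a stated time of 1 h, at pH 7.4 (on this read-out lower numbers stand for lower lipophilicity and higher numbers for higher lipophilicity), compound 3 `Cc1cc(C#N)cnc1C(=O)Nc1ccc(F)c([C@]2(C)C=C(CF)OC(N)=N2)c1` gives 2.5 and stands level with compound 2 `C[C@@]1(c2cc(NC(=O)c3ncc(C#N)cc3Cl)ccc2F)C=C(CF)OC(N)=N1` at 2.5 while compound 1 `C[C@@]1(c2cc(NC(=O)c3cnc(OCF)cn3)ccc2F)C=C(CF)OC(N)=N1` gives 2.6 within the scatter of both. Compound 4 `C[C@@]1(c2cc(NC(=O)c3coc(C(F)F)n3)ccc2F)C=C(CF)OC(N)=N1` differs from compound 3 on a carbonyl carbon: 2-(difluoromethyl)-1,3-oxazol-4-yl in place of 5-cyano-3-methylpyridin-2-yl on a carbonyl carbon is the change, with 2-(difluoromethyl)-1,3-oxazol-4-yl entering in place of 5-cyano-3-methylpyridin-2-yl. Swaps at that same place gave a number 0.10 log units lower from compound 1 to compound 2 (within the scatter) and a number 0.10 log units lower from compound 1 to compound 3 (within the scatter) while methyl in place of chloro gave no change at the digits printed from compound 2 to compound 3 (within the scatter) and all three stayed within the scatter. None of them brought in a five-membered aromatic ring, so the forecast remains uncertain. No step beyond the scatter is expected, and the estimated move is a number 0.10 log units lower from compound 3 to compound 4 (within the scatter) in this assay for now. For compound 4 the estimated value is 2.4 with an expected range from 2 to 2.8 in this measurement.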

Compound 4, distribution coefficient: 2.6
Compound 4: middle estimate off by 0.20 log units, on the low side; measured number inside the range.
By their numbers in this assay, from the lowest: compounds 2, 3, 1 and 4 (each within the scatter of the next).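

Putting a five-membered aromatic ring on this carbonyl carbon gives a number 0.10 log units higher from compound 3 to compound 4 (within the scatter) and a number 0.10 log units higher from compound 2 to compound 4 (within the scatter) and no change at the digits printed from compound 1 to compound 4 (within the scatter) in this assay with 2-(difluoromethyl)-1,3-oxazol-4-yl as the entering group. This place has therefore now carried both six-membered and five-membered aromatic rings, and no step among these four compounds lies beyond the scatter. No evidence here explains why these numbers stay so close.

An amine or a carboxylic acid at this place remains an open case, as the compounds shown carry only aromatic rings there.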